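A few compounds are considered here, and "the series" means these few. Any claim that something is new, unique, unknown or untested is made for them only; others in the source may bear on it.

Working notes on a carbamate series followed in an assay on NIH3T3 cells with Urotensin-2 receptor (Homo sapiens) as the target; a higher number here means that more compound is needed for the effect, a lower number that less compound is needed. Compound 1 `Cc1ccccc1NC(=O)OC(CCN(C)C)c1ccc(Cl)cc1` gives 3890 nM. Compound 2 `COc1ccc(NC(=O)OC(CCN(C)C)c2ccc(Cl)cc2)cc1` gives 1660 nM in this assay. Compound 3 `CN(C)CCC(OC(=O)Nc1ccc(C(C)(C)C)cc1)c1ccc(Cl)cc1` gives 1820 nM. Among the compounds with values here, compound 2 holds the lowest of the three numbers, but its gap to compound 3 (a 1.1-fold higher number from compound 2 to compound 3 (0.04 log units; within the scatter)) lies within the scatter, and only one step, a 2.3-fold lower number from compound 1 to compound 2 (0.37 log units; beyond the scatter), is beyond it, so it cannot be called the most potent.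

Compound 4 `COc1cccc(NC(=O)OC(CCN(C)C)c2ccc(Cl)cc2)c1` is not yet measured. It differs from compound 2 in one place: 3-methoxyphenyl in place of 4-methoxyphenyl on an amide-type nitrogen. Within the data shown here, no measured step shifts the methoxy from one ring position to another. The nearest comparisons are the replacement of 2-methylphenyl by 4-methoxyphenyl, a 2.3-fold lower number from compound 1 to compound 2 (0.37 log units; beyond the scatter), a modest step, and the replacement of methoxy by tert-butyl, a 1.1-fold higher number from compound 2 to compound 3 (0.04 log units; within the scatter), within the scatter. Changing the aryl group on this nitrogen has so far given at most a modest shift, so for compound 4 a small step in this assay is expected, more likely toward a higher number than a lower one. Compound 4 is estimated at 2400 nM, with a range of 1000 nM to 6000 nM. This estimate corresponds to an expected step of a 1.4-fold higher number from compound 2 to compound 4 (0.16 log units; within the scatter).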

Compound 4, half-maximal effective concentration: 1120 nM
Beside the measured number, compound 4's estimate is 2.1-fold (0.33 log units) above it, and the stated range covers the measured number.
By their numbers in this assay, from the lowest: compounds 4, 2 and 3 (each within the scatter of the next); then compound 1.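

In this assay, within the data shown here, the change from 4-methoxyphenyl to 3-methoxyphenyl on the amide-type nitrogen gives the first direct comparison of two placements of one group on this aryl ring: a 1.5-fold lower number from compound 2 to compound 4 (0.17 log units; within the scatter), so these two methoxyphenyl groups cannot be told apart here. The change from 2-methylphenyl to 3-methoxyphenyl gives a 3.5-fold lower number from compound 1 to compound 4 (0.54 log units; beyond the scatter), so both methoxyphenyl compounds now stand apart from compound 1 by steps beyond the scatter. No supporting data bear on the reason for these numbers.

Compound 1 differs from compound 4 in both the substituent and its ring position, so the compounds shown do not separate these two contributions. As far as these compounds go, how an amine or a carboxylic acid in place of methoxy on this aryl ring would read in this assay also stays open.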